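The source may report more compounds than this note shows. Statements on the series, on what has been measured and on what is new or still open speak of the compounds shown alone.

Compound 3, `CN(C)c1nccc2c1ncn2C1O[C@H](CO)[C@@H](O)[C@H]1O`, is the reference point for the next step. For the measured compounds named here, in a functional assay on EL4 cells (Mus musculus) for inhibition, tested at 100 uM (a higher number here means more inhibition at the concentration tested (going by the name of the read-out), a lower number less inhibition), compound 3 gives 10%, the second highest of the three numbers measured so far. Its nearest neighbour is compound 1, `OC[C@H]1OC(n2cnc3c(NCc4ccccc4)nccc32)[C@H](O)[C@@H]1O`, which in this assay gives 5%; the step of a number 5 percentage points higher from compound 1 to compound 3 (within the scatter) lies within the scatter. The furthest is compound 2, `OC[C@H]1OC(n2cnc3c(SCc4ccccc4)nccc32)[C@H](O)[C@@H]1O`, which in this assay gives 30%; the step of a number 20 percentage points lower from compound 2 to compound 3 (beyond the scatter) is beyond the scatter, as is a number 25 percentage points higher from compound 1 to compound 2 (beyond the scatter).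

Compound 4 is `OCCNc1nccc2c1ncn2C1O[C@H](CO)[C@@H](O)[C@H]1O`. The change from compound 3 is (2-hydroxyethyl)amino in place of dimethylamino on an aromatic carbon. Going by the values given here, no measured step exchanges one amino substituent for another of this kind; the closest information is the step of a number 5 percentage points higher from compound 1 to compound 3 (within the scatter), which shows two different amino substituents on the shared core with no difference beyond the scatter, while only the benzylsulfanyl compound 2 stands apart. Since compound 4 keeps an amino substituent at this position, the estimated step of a number 2 percentage points lower from compound 3 to compound 4 (within the scatter) is expected to stay within the scatter. For compound 4 the expected value in this assay is 8%, with a range of 0% to 20%.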

Compound 4, a percentage reported as inhibition, at one concentration (the size of the read-out at that concentration, not a potency): 6%
For compound 4 the middle estimate is 2 percentage points above the measured one; the range from low to high includes it.
By their numbers in this assay, from the lowest: compounds 1, 4 and 3 (each within the scatter of the next); then compound 2.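

Adding (2-hydroxyethyl)amino in place of dimethylamino gives the step of a number 4 percentage points lower from compound 3 to compound 4 (within the scatter) in this assay, so a hydroxyl-bearing chain on this aromatic carbon reads the same as the dialkylamino group. The step of a number 1 percentage points higher from compound 1 to compound 4 (within the scatter), with hydroxymethyl in place of phenyl on the chain bound to the nitrogen, shows that the phenyl ring of benzylamino makes no difference that can be read here. With the step of a number 24 percentage points lower from compound 2 to compound 4 (beyond the scatter), three amino substituents now sit together, and the benzylsulfanyl group is the one exception to that level.

On these data alone, whether the sulfur link or the whole benzylsulfanyl group sets this exception apart stays open, and a methylsulfanyl or benzyloxy group at this carbon would separate the two. No measurement at hand offers a reason for the gap between the benzylsulfanyl and amino substituents.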